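The source may report more compounds than this note shows. Statements on the series, on what has been measured and on what is new or still open speak of the compounds shown alone.

Measured so far, in an ADME assay on HELF cells (Homo sapiens) for cytotoxicity, with a stated time of 3 days; a higher number here means that more compound is tolerated, a lower number that less compound is tolerated:
Compound 1 `C[C@H](NC(=O)[C@]1(Cc2ccccc2)CCN1S(=O)(=O)c1ccc2ccccc2c1)C(N)=O` gives > 100000 nM, a limit of the assay.
Compound 2 `C[C@H](NC(=O)[C@]1(Cc2ccccc2)CCN1C(=O)OCc1ccccc1)C(=O)NC1CCCCC1` gives > 100000 nM, a limit of the assay.
Compound 3 `C[C@H](NC(=O)[C@@]1(Cc2ccccc2)CCN1C(=O)OCc1ccccc1)C(=O)NC1CCCCC1` gives 46000 nM.

Where compound 2 stands: in this assay compound 2 reports only a limit, > 100000 nM, and no number. The same holds for compound 1, so that two of the three values sit at the limit of > 100000 nM in this assay, at which 2 of the 3 values shown sit. Among the measured compounds shown here, compound 3 alone gives a number, and the one measured step, an at least 2.1-fold lower number from compound 2 to compound 3 (0.33 log units; beyond the scatter), rests on (the fact that compounds 2 and 3 differ only in the configuration as drawn).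

Compound 4 `C[C@H](NC(=O)[C@]1(Cc2ccccc2)CCN1C(=O)OCc1ccccc1)C(=O)NCc1ccccc1` differs from compound 2 by benzyl in place of cyclohexyl on an amide-type nitrogen. For the measured compounds named here, no measured step touches this amide substituent; the only step, an at least 2.1-fold lower number from compound 2 to compound 3 (0.33 log units; beyond the scatter), is a change of configuration and does not bear on it. With compound 2 at the limit and no contrary evidence on this position, compound 4 is expected to stay near the limit, so the expected step is a number no higher from compound 2 to compound 4 (the limit leaves the size open), none beyond the scatter. The estimate for compound 4 is 100000 nM, with a range from 40000 nM to 250000 nM.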

Compound 4, half-maximal cytotoxic concentration: 42000 nM
The estimate for compound 4 lay 2.4-fold (0.38 log units) above the measured number; the measured number falls inside the stated range.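

In this assay the amide-type nitrogen proves to be a position that responds to its substituent: benzyl in place of cyclohexyl gives an at least 2.3-fold lower number from compound 2 to compound 4 (0.37 log units; beyond the scatter). Among the compounds shown here, the only earlier step was a change of configuration, so this is the first step beyond the scatter that comes from a change of group, with the configuration as drawn in compound 2 kept. Only a lower bound on its size can be read, because one end of the step is not a number: the limit of > 100000 nM in this assay, at which 2 of the 4 values shown sit.

The compounds shown do not separate the aromatic ring of benzyl from the added carbon, and a cyclohexylmethyl or phenyl group on this nitrogen would bear on that. Also open, going by these compounds, is whether the benzyl step holds with the configuration drawn in compound 3.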